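Working notes: 3-fluorophenyl in place of 4-iodophenyl

A few compounds are considered here, and "the series" means these few. Any claim that something is new, unique, unknown or untested is made for them only; others in the source may bear on it.

All values below come from a functional assay on MCF7 cells (Homo sapiens) for inhibition, read by sulforhodamine B assay; a higher number here means a weaker inhibitor, a lower number a stronger inhibitor.

Compound 1, `CCOc1ccc(NC2=CC(=O)c3c(nc4n3[C@H]3OC[C@@H](O)[C@H]3OC4)C2=O)cc1`: only a limit, > 4000 nM.
Compound 2, `O=C1C(Nc2ccc(C(F)(F)F)cc2)=CC(=O)c2c1nc1n2[C@H]2OC[C@@H](O)[C@H]2OC1`: only a limit, > 4000 nM.
Compound 3, `O=C1C(Nc2ccc(I)cc2)=CC(=O)c2c1nc1n2[C@H]2OC[C@@H](O)[C@H]2OC1`: 3890 nM.
Compound 4, `O=C1C(Nc2cccc(F)c2)=CC(=O)c2c1nc1n2[C@H]2OC[C@@H](O)[C@H]2OC1`: not yet measured.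

For the measured compounds named here, compound 3 holds the only number in this assay; the two other compounds sit at the limit of > 4000 nM in this assay, at which 2 of the 3 values shown sit. The step of an at least 1.0-fold lower number from compound 1 to compound 3 (0.01 log units; that floor lies within the scatter) and the step of an at least 1.0-fold lower number from compound 2 to compound 3 (0.01 log units; that floor lies within the scatter) are therefore floors only, and both floors lie within the scatter, so compound 3 cannot be set apart from compound 1 or compound 2 on these data. The step that the two limits leave unreadable from compound 1 to compound 2 is not readable at all.

The next step, (3-fluorophenyl in place of 4-iodophenyl on an amine nitrogen), again changes the group on the ring. The measured steps bearing on it are those just named, and none of them gives a readable size or direction, so no direction beyond the scatter can be expected for compound 4; the step of a 1.2-fold higher number from compound 3 to compound 4 (0.06 log units; within the scatter) is an estimate that keeps the number near that of compound 3. Compound 4 is thus expected to give about 4500 nM in this assay, within a range from 2000 nM to 12000 nM, with a fair chance that only a limit is returned.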

Compound 4, half-maximal inhibitory concentration: > 4000 nM
Compound 4 gave a limit, no number; the forecaster's own chance of this, stated with the estimate: 50%; the middle value lies beyond the limit too.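

In this assay, 3-fluorophenyl in place of 4-iodophenyl on the amine nitrogen yields only a floor, an at least 1.0-fold higher number from compound 3 to compound 4 (0.01 log units; that floor lies within the scatter), so compound 4 cannot be set apart from compound 3. The steps from compound 1 and from compound 2 to compound 4 join two limits and cannot be read. The new information is that 3-fluorophenyl, the only group shown here with its name numbered 3 rather than 4, also gives no number, and the series now gathers at a single limit: the limit of > 4000 nM in this assay, at which 3 of the 4 values shown sit.

The compounds shown leave open how far compound 1, compound 2 and compound 4 lie past that limit, so no order can be drawn among the four compounds. They also leave open whether an amine or a carboxylic acid on the phenyl ring, or a longer chain in place of that ring, would give a number in this assay that stands clear of compound 3.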